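This account rests on a few compounds, and the source may have more. Where it says the series, first, only, none or still open, it means among the compounds named here.

In a toxicity assay on HeLa cells (Homo sapiens) for cytotoxicity, read by colorimetric assay, with a stated time of 72 h (a higher number here means that more compound is tolerated, a lower number that less compound is tolerated), compound 1 `O=c1nc(N2CCC(CCO)CC2)sc2c([N+](=O)[O-])cc(C(F)(F)F)cc12` gives 91500 nM as a measured number. Compound 2 `CC(=O)c1ccc(N2CCN(c3nc(=O)c4cc(C(F)(F)F)cc([N+](=O)[O-])c4s3)CC2)cc1` gives > 105000 nM as its reading, and this is a limit of the assay, not a number. As far as these compounds go, its exact place on the scale stays unknown.

Compound 3 `O=C(CN1CCN(c2nc(=O)c3cc(C(F)(F)F)cc([N+](=O)[O-])c3s2)CC1)NCc1ccccc1` is the next to be measured. It keeps the core of compound 2 and changes one group: (benzylcarbamoyl)methyl in place of 4-acetylphenyl on an amine nitrogen in a ring. Among the measured compounds shown here, both groups carry a six-membered aromatic ring of carbon only, and no measured pair of compounds here shows what such a swap does.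

In this assay no change beyond the usual scatter is expected, and the estimated step of an at least 1.1-fold lower number from compound 2 to compound 3 (0.06 log units; that floor lies within the scatter) is a small one, towards slightly less compound tolerated. This expectation also leans on compound 1 with its value of 91500 nM on the same scale, which has a different group on the shared core. For compound 3 the estimated value is 90000 nM, with an expected range from 40000 nM to 120000 nM.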

Compound 3, half-maximal cytotoxic concentration: 57100 nM
Compound 3: middle estimate off by 1.6-fold (0.20 log units), on the high side; low and high end bracket the measured number.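

In this assay, (benzylcarbamoyl)methyl in place of 4-acetylphenyl on the amine nitrogen in the ring gives an at least 1.8-fold lower number from compound 2 to compound 3 (0.26 log units; that floor lies within the scatter). Among the compounds shown here, the reading of compound 2 is a limit of the assay, not a number, so this step is only a floor and the real distance on the scale stays unknown: the limit of > 105000 nM in this assay, at which 1 of the 3 values shown sits. Compound 3 therefore provides the first measured number for a compound with a group on this nitrogen of the six-membered ring with 2 nitrogen, and the group that enters carries a hydrogen-bond donor where the group that leaves has none.

A single swap cannot separate the parts of the new group, so the amide hydrogen, the carbonyl and the aromatic ring may each matter or may not matter at all for how much compound the cells tolerate. As far as these compounds go, it also stays open whether a simple amine, a carboxylic acid or a longer chain on this nitrogen would shift the reading beyond the usual scatter, and in which direction.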